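The compounds below may be only part of what the source reports. "The series", "measured", "known", "first", "only" and "open" are said of these compounds alone.

In a functional assay on HL-60 cells (Homo sapiens) for inhibition, read by CCK-8 assay, with a stated time of 48 h, tested at 20 uM (a lower number here means less inhibition of growth, a higher number more inhibition of growth at the concentration tested), compound 1 (`Cc1ccc(S(=O)(=O)Oc2ccccc2/C=C(\C#N)C(=O)Nc2nnc(Cc3ccc(F)cc3)s2)cc1`) is reported as "not active" (no number reported) and carries no number. Compound 2 (`N#C/C(=C\c1ccccc1OS(=O)(=O)c1ccc(Cl)cc1)C(=O)Nc1nnc(Cc2ccc(F)cc2)s1`) gives 20% there, the only number shown in this set. Compound 3 (`N#C/C(=C\c1ccccc1OS(=O)(=O)c1ccc(Cl)cc1)C(=O)Nc1nnc(Cc2ccc(Cl)cc2)s1`) departs from compound 2 by one change (chloro in place of fluoro on an aromatic carbon), chloro in place of fluoro on an aromatic carbon, para to a large group. Among the measured compounds shown here, no measured step is available as a guide, so no step beyond the scatter is expected in this assay in either direction. For compound 3 the estimate is 20% within a range of 5% to 40% for repeated measurements. The estimated change stays inside the usual scatter (no change at the digits printed from compound 2 to compound 3 (within the scatter)).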

Compound 3, percent growth inhibition at one concentration: 15%
The estimate for compound 3 lay 5 percentage points above the measured number; the range from low to high includes it.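

In this assay, among the compounds shown here, the change from 4-fluorobenzyl to 4-chlorobenzyl gives a number 5 percentage points lower from compound 2 to compound 3 (within the scatter), the first step in this set that can be read. At this place, on an aromatic carbon para to a large group, chloro in place of fluoro therefore leaves the read-out within the scatter. Nothing available bears on why this is so.

Compound 1 carries no number, so its step to compound 2 cannot be read. From the compounds shown here alone, whether an amine or a carboxylic acid at this place would give a different result remains open.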